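The compounds below may be only part of what the source reports. "The series", "measured", "known", "first", "only" and "open" are said of these compounds alone.

Compound 1 `Cc1ccc(Cn2cc(CSC(=S)N3CCN(C(=O)OCc4ccccc4)CC3)nn2)cc1` and compound 2 `O=C(OCc1ccccc1)N1CCN(C(=S)SCc2cn(Cc3ccccc3F)nn2)CC1` share one core and differ only in the aromatic ring that sits on a saturated chain carbon bound to an aromatic nitrogen. In a functional assay on ECa-109 cells (Homo sapiens) for inhibition, read by MTT assay, with a stated time of 72 h (a lower number here means a stronger inhibitor, a higher number a weaker inhibitor), compound 1 gives 32600 nM, and compound 2 gives 27000 nM. For the measured compounds named here, the step between them, a 1.2-fold lower number from compound 1 to compound 2 (0.08 log units; within the scatter), does not separate the two, so in this assay compound 2 stands level with compound 1, the only other compound measured. Compound 3 `O=C(OCc1ccccc1)N1CCN(C(=S)SCc2cn(Cc3ccc(Cl)c(Cl)c3)nn2)CC1` keeps the core of compound 2 and changes the same ring: 3,4-dichlorophenyl in place of 2-fluorophenyl on a saturated chain carbon bound to an aromatic nitrogen. Going by the values given here, the only measured step that bears on this change is the exchange of 4-methylphenyl for 2-fluorophenyl at this place, and it left this assay essentially unchanged; no measured step speaks to two chlorines on that ring, so the direction of any effect is unknown. The expectation is therefore no step beyond the scatter, and the estimated change is a 1.1-fold lower number from compound 2 to compound 3 (0.03 log units; within the scatter). For compound 3 the estimated value in this assay is 25000 nM, with a range from 8000 nM to 80000 nM.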

Compound 3, half-maximal inhibitory concentration: 29400 nM
Beside the measured number, compound 3's estimate is 1.2-fold (0.07 log units) below it; the range from low to high includes it.
By their numbers in this assay, from the lowest: compounds 2, 3 and 1 (each within the scatter of the next).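

With two chlorines on the ring, the picture at this position does not change: 3,4-dichlorophenyl in place of 2-fluorophenyl gives a 1.1-fold higher number from compound 2 to compound 3 (0.04 log units; within the scatter), and 3,4-dichlorophenyl in place of 4-methylphenyl gives a 1.1-fold lower number from compound 1 to compound 3 (0.04 log units; within the scatter). For the compounds shown here, until now only one exchange of aromatic groups could be read here, whereas compounds 1, 2 and 3 now stand level with one another in this assay, whether the phenyl ring on the saturated chain carbon bound to an aromatic nitrogen bears a methyl group, a fluorine or two chlorines, and none of the three goes against this. Nothing measured here explains why these exchanges leave the number in the scatter.

From the compounds shown here alone, all three compounds keep a phenyl ring with small substituents at this place, so it remains open whether an amine or a carboxylic acid on that ring, or a longer chain in place of the benzyl link, would move the number beyond the scatter. The shared core stays the same throughout, so these compounds also leave open how a change elsewhere in the molecule, rather than at this position, would read in this assay.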